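Swapping phenyl for fluoro on a shared core

A few compounds are considered here, and "the series" means these few. Any claim that something is new, unique, unknown or untested is made for them only; others in the source may bear on it.

Compound 3 `C=C1CC(Cn2ccc(=O)[nH]c2=O)(c2ccc(-c3ccccc3)cc2)OC1=O` is one of three analogues measured in a functional assay on A549 cells (Homo sapiens) for inhibition; on this read-out lower numbers stand for stronger inhibition of growth and higher numbers for weaker inhibition of growth. In this assay compound 3 gives 10700 nM, the lowest of the three numbers shown, while compound 1 `C=C1CC(Cn2cc(C)c(=O)[nH]c2=O)(c2ccc(-c3ccccc3)cc2)OC1=O` gives 12300 nM and compound 2 `C=C1CC(Cn2cc(C)c(=O)[nH]c2=O)(c2ccc(F)cc2)OC1=O` gives 17800 nM, both of them within the scatter of compound 3. Compound 4 `C=C1CC(Cn2ccc(=O)[nH]c2=O)(c2ccc(F)cc2)OC1=O` has not yet been measured. The change from compound 3 to compound 4 is fluoro in place of phenyl on an aromatic carbon. The same swap has been seen once before in this set: a 1.4-fold higher number from compound 1 to compound 2 (0.16 log units; within the scatter). The other step, a 1.1-fold lower number from compound 1 to compound 3 (0.06 log units; within the scatter), concerns the methyl-to-hydrogen change that compounds 3 and 4 share relative to compounds 1 and 2 and does not bear on the swap itself. For the measured compounds named here, with only one prior step, and that one within the scatter, no step beyond the scatter is expected for compound 4, at most a slightly higher number. Compound 4 is therefore estimated at 15000 nM, in the range 7000 nM to 32000 nM. This corresponds to an expected step of a 1.4-fold higher number from compound 3 to compound 4 (0.15 log units; within the scatter).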

Compound 4, concentration for 50% growth inhibition: 17000 nM
Compound 4: the middle estimate sits 1.1-fold (0.05 log units) below what was measured; the measured number falls inside the stated range.
By their numbers in this assay, from the lowest: compounds 3, 1, 4 and 2 (each within the scatter of the next).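

In this assay, fluoro in place of phenyl on the core without the methyl gives a 1.6-fold higher number from compound 3 to compound 4 (0.20 log units; within the scatter), so this swap can now be read on two cores, and it stays within the scatter on both: the same change on two cores in this assay, a 1.4-fold higher number (0.16 log units; within the scatter) from compound 1 to compound 2 and a 1.6-fold higher number (0.20 log units; within the scatter) from compound 3 to compound 4, 1.1-fold (0.04 log units) apart, within the scatter of two such steps

Hydrogen in place of methyl, so far read only with phenyl on the aromatic ring, can now also be read with fluoro there, where it gives a 1.0-fold lower number from compound 2 to compound 4 (0.02 log units; within the scatter), again within the scatter: the same change on two cores in this assay, a 1.1-fold lower number (0.06 log units; within the scatter) from compound 1 to compound 3 and a 1.0-fold lower number (0.02 log units; within the scatter) from compound 2 to compound 4, 1.1-fold (0.04 log units) apart, within the scatter of two such steps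

Across these four compounds, neither change moves the number beyond the scatter, and neither change alters the size of the other beyond it.

The compounds shown therefore do not identify any group at either place that shifts the number beyond the scatter. As far as these compounds go, whether an amine or a carboxylic acid in place of fluoro, or a longer chain in place of the methyl, would do so remains open.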